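Azetidine amide series: aryl in place of cyclohexyl

The source may hold more compounds than are shown below. What is called first, only, known or untested is meant among the compounds shown, and "the series" means these compounds.

Two compounds have numbers in an assay on HEK293 cells for positive allosteric modulation of metabotropic glutamate receptor 5 (Homo sapiens), read by FLIPR; on this read-out lower numbers stand for an effect already at smaller amounts and higher numbers for an effect only at larger amounts of compound. Compound 1, `O=C([C@H]1CC2CCC1C2)N1CC(c2nc(-c3ccccc3)no2)C1`, gives 120 nM there. Compound 2, `CC1CCC(C(=O)N2CC(c3nc(-c4cccc(Cl)c4)no3)C2)CC1`, gives 1500 nM in this assay and so stands at the higher end of the two values, well apart from compound 1; the two differ in more than one place, so no single change can be read from the pair.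

Compound 3, `O=C(c1ccc(F)cc1)N1CC(c2nc(-c3cccc(Cl)c3)no2)C1`, is the next compound to be measured in this assay. It differs from compound 2 in one place: 4-fluorophenyl in place of 4-methylcyclohexyl on a carbonyl carbon. The rest of the molecule, including the chlorophenyl-bearing part, stays as in compound 2.

For the measured compounds named here, no measured pair isolates this kind of exchange, so the direction and size of the step can only be estimated. In this assay the step from compound 2 to compound 3 is expected to be a 2.5-fold lower number from compound 2 to compound 3 (0.40 log units; beyond the scatter), a move toward lower numbers that is likely to exceed the scatter but not to reach the number of compound 1. For compound 3 the estimate in this assay is 600 nM, with a range from 150 nM to 3000 nM.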

Compound 3, half-maximal effective concentration: > 10000 nM
Compound 3: a limit, no number; the forecaster's own chance of this, stated with the estimate: 10%; at least 16-fold (1.22 log units) between middle value and limit.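

In this assay, for the compounds shown here, the exchange of 4-methylcyclohexyl for 4-fluorophenyl on the carbonyl carbon is the first change that can be read in one place, and it gives an at least 6.6-fold higher number from compound 2 to compound 3 (0.82 log units; beyond the scatter). Compound 3 has a limit of the assay, > 10000 nM, and not a number. The place on the carbonyl carbon is therefore not indifferent to this exchange, even though both groups hold a six-membered ring and the same count of heavy atoms, and the full size of the step stays unknown: the limit of > 10000 nM in this assay, at which 1 of the 3 values shown sits.

Open, as far as these compounds go, is whether a plain phenyl or a plain cyclohexyl on the carbonyl carbon would separate the part played by the aromatic ring from that of the fluorine or the methyl. Also open, from the compounds shown here alone, is whether the group on the carbonyl carbon of compound 1 would keep its standing when paired with the chlorophenyl-bearing part of compound 2, and whether an amine on the ring at this place would be tolerated at all.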